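This account rests on a few compounds, and the source may have more. Where it says the series, first, only, none or still open, it means among the compounds named here.

Compound 1 `COC(=O)c1cn(C/C=C(/C)CC/C=C(\C)CCC=C(C)C)nn1` has been measured in a physicochemical assay for lipophilicity, measured as octanol-water partition (on this read-out lower numbers stand for lower lipophilicity and higher numbers for higher lipophilicity), and gives 5.25. Among the three compounds with a number, compound 1 stands lowest. Compound 2 `CC(C)=CCC/C(C)=C/CC/C(C)=C\Cn1cc(-c2ccccc2)nn1` gives 6.95 in this assay, and compound 3 `CCCc1cn(C/C=C(/C)CC/C=C(\C)CCC=C(C)C)nn1` gives 6.5. The steps of a number 1.70 log units higher from compound 1 to compound 2 (beyond the scatter) and a number 1.25 log units higher from compound 1 to compound 3 (beyond the scatter) are both large, and a number 0.45 log units lower from compound 2 to compound 3 (beyond the scatter) is modest; all three exchange the group on the aromatic carbon of the shared core and leave the chain as it is.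

Compound 4 `COC(=O)c1cn(C/C=C(/C)CCC=C(C)C)nn1` has not yet been measured in this assay. It differs from compound 1 in the chain: hydrogen in place of 3-methylbut-2-en-1-yl on a saturated chain carbon bound to a double-bonded chain carbon. Within the data shown here, none of the measured steps touches the chain, so none bears directly on this change, and the methoxycarbonyl group stays in place. Because compound 1 already gives 5.25 and part of the chain leaves, compound 4 is expected to move further down, by a number 1.80 log units lower from compound 1 to compound 4 (beyond the scatter). Compound 4 is therefore estimated at 3.45, within a range of 2.9 to 4.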

Compound 4, partition coefficient: 3.2
Compound 4: middle estimate off by 0.25 log units, on the high side; measured number inside the range.
By their numbers in this assay, from the lowest: compound 4; then compound 1; then compound 3; then compound 2.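

In this assay, hydrogen in place of 3-methylbut-2-en-1-yl on a saturated chain carbon bound to a double-bonded chain carbon gives a number 2.05 log units lower from compound 1 to compound 4 (beyond the scatter), the only step shown that touches the chain. The chain is therefore a place where the number can shift by a large step, and this step runs in the opposite direction to the two shown on the aromatic carbon, a number 1.70 log units higher from compound 1 to compound 2 (beyond the scatter) and a number 1.25 log units higher from compound 1 to compound 3 (beyond the scatter). No evidence at hand explains this step.

Among these compounds, with only one step in the chain, the compounds leave open how the number follows a longer chain, and whether the same loss of 3-methylbut-2-en-1-yl gives a similar step with phenyl or propyl on the aromatic carbon. They also leave open where the number would fall with a carboxylic acid or an amine on that carbon.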